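A Pyrazole Replaces a Fluoromethoxyphenyl Group on the Core

The source may report more compounds than this note shows. Statements on the series, on what has been measured and on what is new or still open speak of the compounds shown alone.

Compound 1 `COc1ccc(-n2c(=O)n(Cc3cc4cc(Cl)ccc4n3CCCC#N)c3cnccc32)c(F)c1` was tested in an ADME assay on HeLa cells (Homo sapiens) for cytotoxicity, read by ATP content, with a stated time of 3 days; on this read-out higher numbers stand for lower toxicity in this test and lower numbers for higher toxicity in this test. In this assay compound 1 returns > 50000 nM, which is a limit of the assay rather than a number. Compound 2 `O=c1n(Cc2cc3cnccc3n2CCCC(F)(F)F)c2cnccc2n1C1CC1` likewise gives only a limit in this assay, > 50000 nM. Compound 3 `CC(C)(C)n1c(=O)n(Cc2cc3cc(Cl)ccc3n2CCCS(C)(=O)=O)c2cnccc21` also shows in this assay nothing but a limit, > 50000 nM. Compound 1 therefore stands exactly where the other two measured compounds stand, since all three share (the limit of > 50000 nM in this assay, at which 3 of the 3 values shown sit), and no number sets any of them apart.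

Compound 4 `Cn1ccc(-n2c(=O)n(Cc3cc4cc(Cl)ccc4n3CCCC#N)c3cnccc32)n1` is not yet measured. It differs from compound 1 in one place: 1-methyl-1H-pyrazol-3-yl in place of 2-fluoro-4-methoxyphenyl on an aromatic nitrogen. Going by the values given here, no measured step between compounds differing in a single place is available, so no measured size of effect can be drawn on. Compound 4 is expected to stay at the limit as well, and the estimate means a step that the limit leaves unreadable from compound 1 to compound 4, no step beyond the scatter. Compound 4 is accordingly estimated at 60000 nM, within 20000 nM to 150000 nM, and the assay is expected most likely to report only a limit again.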

Compound 4, half-maximal cytotoxic concentration: > 50000 nM
Compound 4: only a limit was reported (the forecaster's own chance of this, stated with the estimate: 85%); the middle value is on the limit's open side.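

Going by these compounds alone, compound 1 and compound 4 both give only a limit in this assay, so no step between them can be read: the limit of > 50000 nM in this assay, at which 4 of the 4 values shown sit.

The compounds shown leave open whether 1-methyl-1H-pyrazol-3-yl in place of 2-fluoro-4-methoxyphenyl changes the half-maximal cytotoxic concentration at all.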